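Swapping the Chain on the Aromatic Nitrogen: Compound 3 to Compound 4

This account rests on a few compounds, and the source may have more. Where it says the series, first, only, none or still open, it means among the compounds named here.

Three compounds have been measured in a functional assay on the whole organism with Rattus norvegicus as the target; a higher number here means that more compound is needed for the effect, a lower number that less compound is needed:

Compound 1, `C[Si](C)(C)c1ccc2nc(N)sc2c1`: 5 mg/kg
Compound 2, `Nc1nc2ccc(OC(F)(F)C(F)(F)F)cc2s1`: 2.5 mg/kg
Compound 3, `N=c1sc2cc(OC(F)(F)F)ccc2n1CC(N)=O`: 7 mg/kg

Compound 3 has the highest of the three numbers. Compound 1 lies nearest to it, with a somewhat lower number, and the two fall within the usual scatter of this assay, so no order can be read between them. Compound 2 lies furthest from compound 3, with a lower number that does stand beyond the scatter, so compound 2 needs less of the substance than compound 3 for the same effect.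

Compound 4, `C[S+]([O-])CCn1c(=N)sc2cc(OC(F)(F)F)ccc21`, is not yet measured. It differs from compound 3 in one place: a group of 4 heavy atoms (2 carbon, 1 oxygen, 1 sulfur; no ring) in place of a group of 3 heavy atoms (1 carbon, 1 nitrogen, 1 oxygen; no ring), on a saturated chain carbon bound to an aromatic nitrogen

Going by the values given here, no pair of measured compounds differs in this way, so the size of this step cannot be read from the data. Both chains hang from the same saturated carbon bound to the aromatic nitrogen, and the rest of the structure is unchanged, so the step from compound 3 to compound 4 in this assay is expected to stay within the scatter, in either direction.

Compound 4 is therefore estimated at 6 mg/kg, with a range from 2 mg/kg to 18 mg/kg, which is expected to mean a step of a 1.2-fold lower number from compound 3 to compound 4 (0.07 log units; within the scatter).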

Compound 4, dose for half-maximal effect: 1.1 mg/kg
Compound 4: the middle estimate sits 5.5-fold (0.74 log units) above what was measured; measured number outside the range, below it.
By their numbers in this assay, from the lowest: compound 4; then compounds 2, 1 and 3 (each within the scatter of the next, the first and the last beyond it).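

Replacing the carbamoyl with the group of 4 heavy atoms (2 carbon, 1 oxygen, 1 sulfur), on a saturated chain carbon bound to an aromatic nitrogen, gives a 6.4-fold lower number from compound 3 to compound 4 (0.80 log units; beyond the scatter) in this assay. Going by these compounds alone, this is the first step between compounds that differ in one place, and it shows that this assay responds to what this chain carries, even though the count of heavy atoms rises by only one and the hydrogen-bond acceptor count stays the same while the hydrogen-bond donor of the carbamoyl is lost. Nothing at hand bears on what lies behind this step.

With a single step at this place, the compounds shown cannot separate the loss of the donor from the entry of the sulfur and its oxygen, nor do they tell whether the same change would hold on another core. Going by these compounds, how a sulfone, a thioether, a carboxylic acid or a longer chain at this place would compare with compound 4 also remains open.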